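The source may report more compounds than this note shows. Statements on the series, on what has been measured and on what is new or still open speak of the compounds shown alone.

Measured so far in an assay on HEK293 cells for agonist activity at Bile acid receptor (Homo sapiens); a lower number here means that less compound is needed, a higher number that more compound is needed for the effect:
Compound 1, `O=C(O)c1cccc(C2CC2c2ccc(OCc3c(-c4c(Cl)cccc4Cl)noc3C3CC3)cc2Cl)c1`: 34 nM
Compound 2, `CC(C)n1nc(C(=O)O)cc1C1CC1c1ccc(OCc2c(-c3c(Cl)cccc3Cl)noc2C2CC2)cc1Cl`: 6 nM
Compound 3, `Clc1cc(OCc2c(-c3c(Cl)cccc3Cl)noc2C2CC2)ccc1C1CC1c1ccc(-c2nnn[nH]2)nc1`: 111 nM

Compound 3 gives the highest of the three numbers; the step of a 3.3-fold higher number from compound 1 to compound 3 (0.51 log units; beyond the scatter) and the step of a 19-fold higher number from compound 2 to compound 3 (1.27 log units; beyond the scatter) both run upward to it. Compound 4, `O=C(O)c1ccc(C2CC2c2ccc(OCc3c(-c4c(Cl)cccc4Cl)noc3C3CC3)cc2Cl)cn1`, keeps the pyridine ring of compound 3 and changes (carboxy in place of 1H-tetrazol-5-yl on an aromatic carbon). For the measured compounds named here, no measured pair isolates this exchange; the measured steps swap the whole aryl group at the saturated ring carbon. Compound 1 carries a carboxy on its aryl group and stands below compound 3 by a 3.3-fold higher number from compound 1 to compound 3 (0.51 log units; beyond the scatter), so a carboxy on the pyridine is expected to bring a modest downward step from compound 3, its size uncertain. Compound 4 is therefore estimated at 45 nM (range 15 nM to 130 nM), a step of a 2.5-fold lower number from compound 3 to compound 4 (0.39 log units; beyond the scatter).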

Compound 4, half-maximal effective concentration: 57 nM
Estimate against measurement, compound 4: 1.3-fold (0.10 log units) below; the measured number falls inside the stated range.
By their numbers in this assay, from the lowest: compound 2; then compounds 1, 4 and 3 (each within the scatter of the next, the first and the last beyond it).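

In this assay, for the compounds shown here, carboxy and 1H-tetrazol-5-yl on the pyridine are compared directly for the first time, and the exchange stays within the scatter (a 1.9-fold lower number from compound 3 to compound 4 (0.29 log units; within the scatter)). The 6-carboxypyridin-3-yl and 3-carboxyphenyl groups are likewise not told apart (a 1.7-fold higher number from compound 1 to compound 4 (0.22 log units; within the scatter)). The 3-carboxy-1-isopropyl-1H-pyrazol-5-yl group of compound 2 remains clearly separate from the 6-carboxypyridin-3-yl group (a 9.5-fold higher number from compound 2 to compound 4 (0.98 log units; beyond the scatter)).

Open, as far as these compounds go, is whether a primary amide or a methyl ester on this aromatic carbon would give a number like that of compound 4. Nothing on hand gives a reason for these steps.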